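This account rests on a few compounds, and the source may have more. Where it says the series, first, only, none or still open, it means among the compounds named here.

Working notes on the series. In a functional assay on MGC-803 cells (Homo sapiens) for inhibition, read by sulforhodamine B assay (on this read-out higher numbers stand for weaker inhibition and lower numbers for stronger inhibition), compound 1 `CCc1ccc(NC2=CC(=O)c3nc4n(c3C2=O)[C@H]2OC[C@@H](O)[C@H]2OC4)cc1` gives 1290 nM, and compound 2 `CCOc1ccc(NC2=CC(=O)c3c(nc4n3[C@H]3OC[C@@H](O)[C@H]3OC4)C2=O)cc1` gives 2090 nM. Compound 1 shows the lower of the two numbers, but the gap to compound 2 lies within the usual scatter, so the two cannot be told apart on this read-out. Within the data shown here, no pair of measured compounds differing in a single place is available, so the effect of any one change has not been observed directly.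

Compound 3 `O=C1C=C(N2CCCC2)C(=O)c2c1nc1n2[C@H]2OC[C@@H](O)[C@H]2OC1` has not been measured. It differs from compound 1 by pyrrolidin-1-yl in place of (4-ethylphenyl)amino on a double-bonded ring carbon. Without a measured step of this kind, the expectation rests only on the two numbers shown. For compound 3 a step toward a weaker inhibition, beyond the scatter, is expected, a 3.1-fold higher number from compound 1 to compound 3 (0.49 log units; beyond the scatter). Compound 3 is therefore estimated at 4000 nM, with a range from 1300 nM to 12000 nM.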

Compound 3, half-maximal inhibitory concentration: > 16000 nM
Compound 3 ended at the assay's limit; the forecaster's own chance of this, stated with the estimate: 10%; at least 4.0-fold (0.60 log units) between middle value and limit.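

The only single-place change shown, pyrrolidin-1-yl in place of (4-ethylphenyl)amino on a double-bonded ring carbon, reads as an at least 12-fold higher number from compound 1 to compound 3 (1.09 log units; beyond the scatter), so the group at this position has a large bearing on the read-out. The change removes a six-membered aromatic ring of carbon only and a hydrogen-bond donor together, and this single step cannot separate the two. In this assay compound 3 gives > 16000 nM, which is a limit of the assay and not a number, so the full size of the step stays unknown: the limit of > 16000 nM in this assay, at which 1 of the 3 values shown sits.

The compounds shown leave open whether the loss follows the aromatic ring, the hydrogen-bond donor or both. A cyclohexylamino group would keep the donor without the aromatic ring, and a methyl(phenyl)amino group would keep the aromatic ring without the donor.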